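Pyrazole for phenyl on the amide aryl ring

This account rests on a few compounds, and the source may have more. Where it says the series, first, only, none or still open, it means among the compounds named here.

Measured so far:
compound 1 `CNC(=O)N1CCCc2ccc(NC(=O)c3ccc(-c4ccccc4)cc3)cc21`: 19.7%
compound 2 `CNC(=O)N1CCCc2ccc(NC(=O)c3cccc(-c4cnn(C)c4)c3)cc21`: 71.2%
compound 3 `CNC(=O)N1CCCc2ccc(NC(=O)c3cccc(-c4cnn(C(C)=O)c4)c3)cc21`: 33.6%

In a functional assay on MV4-11 cells (Homo sapiens) for antiproliferative activity, with a stated time of 6 days, tested at 1.56 uM (on this read-out lower numbers stand for a weaker effect and higher numbers for a stronger effect at the one concentration tested), compound 1 stands lowest of the three; compound 3 lies nearer to it and compound 2 furthest away, both beyond the scatter. Compound 4 `CNC(=O)N1CCCc2ccc(NC(=O)c3ccc(-c4cn[nH]c4)cc3)cc21` follows from compound 1 by 1H-pyrazol-4-yl in place of phenyl on an aromatic carbon. Going by the values given here, no measured step covers this exchange directly. Among the compounds with values here, the only single step, a number 37.6 percentage points lower from compound 2 to compound 3 (beyond the scatter), concerns acetyl in place of methyl on an aromatic nitrogen of the pyrazole and is large, showing that the read-out in this assay responds strongly to what the pyrazole carries. The values of compound 2 and compound 3, both bearing a pyrazole, sit above compound 1. An upward step of moderate to large size is therefore expected, a number 30.3 percentage points higher from compound 1 to compound 4 (beyond the scatter). Compound 4 is estimated at 50%, within 25% to 78%.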

Compound 4, a percentage reported as inhibition, at one concentration (the size of the read-out at that concentration, not a potency): 73.5%
Estimate against measurement, compound 4: 23.5 percentage points below; measured number inside the range.
By their numbers in this assay, from the lowest: compound 1; then compound 3; then compounds 2 and 4 (each within the scatter of the next).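

In this assay, 1H-pyrazol-4-yl in place of phenyl on an aromatic carbon para to a large group gives a number 53.8 percentage points higher from compound 1 to compound 4 (beyond the scatter). Going by these compounds alone, this is the first direct read on the ring at this position: the earlier step showed only that a change on the pyrazole nitrogen moves the read-out, whereas this one shows that exchanging the ring itself also does. No available evidence bears on what lies behind this step. The compounds shown leave open whether a pyridin-4-yl or imidazol-4-yl ring at the same place would keep the effect. They also leave open how an aminomethyl group there would compare.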